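A few compounds are considered here, and "the series" means these few. Any claim that something is new, unique, unknown or untested is made for them only; others in the source may bear on it.

Compound 1 `CC1=NNC(=O)C1C(c1c(-c2ccccc2)[nH]c2ccc(C)cc12)c1c(-c2ccccc2)[nH]c2ccc(Cl)cc12` and compound 2 `COc1ccc2[nH]c(-c3ccccc3)c(C(c3c(-c4ccccc4)[nH]c4ccc(C)cc34)C3C(=O)NN=C3C)c2c1` share one core, while compound 3 `CC1=NNC(=O)C1C(c1c[nH]c2ccccc12)c1c(-c2ccccc2)[nH]c2ccc(Cl)cc12` is built on another; the difference between the two cores is not broken down here. In a functional assay on HeLa cells (Homo sapiens) for cytotoxicity, read by MTT assay (on this read-out lower numbers stand for stronger inhibition and higher numbers for weaker inhibition), compound 1 gives > 100000 nM, which is a limit of the assay. In this assay compound 2 gives > 100000 nM, again a limit. Compound 2 differs from compound 1 by a methoxy in place of chloro on an aromatic carbon, and the step that the two limits leave unreadable from compound 1 to compound 2 cannot be read since both values sit at the limit of > 100000 nM in this assay, at which 2 of the 3 values shown sit. In this assay, for the measured compounds named here, compound 3 gives 3800 nM, the only number among the three. Compound 4 `COc1ccc2[nH]c(-c3ccccc3)c(C(c3c[nH]c4ccccc34)C3C(=O)NN=C3C)c2c1` carries the same change relative to compound 3, a methoxy in place of chloro on an aromatic carbon. The measured pair therefore offers no readable size for this change. For compound 4 in this assay a step of a 1.6-fold higher number from compound 3 to compound 4 (0.20 log units; within the scatter) is expected. That expectation rests on compound 3 at 3800 nM as the only numbered starting point. Compound 4 is accordingly estimated at 6000 nM, within a range from 1500 nM to 30000 nM.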

Compound 4, half-maximal inhibitory concentration: 1700 nM
For compound 4 the middle estimate is 3.5-fold (0.55 log units) above the measured one, and the stated range covers the measured number.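

In this assay, methoxy in place of chloro on the core of compound 3 gives a 2.2-fold lower number from compound 3 to compound 4 (0.35 log units; beyond the scatter), a modest step seen in this single pair. The same change on the core of compound 1 offers no readable step for comparison, because both of its values are limits of the assay: the limit of > 100000 nM in this assay, at which 2 of the 4 values shown sit.

The result therefore shows that, on the core of compound 3, the methoxy compound keeps a measurable value and sits lower than the chloro compound, but it does not show that either the size or the direction of this step carries over from one core to another. Going by these compounds, it remains open whether the lower number is particular to methoxy, or whether another group on that aromatic carbon, such as an ethoxy or a hydroxyl, would give a similar step. On these data alone, it is also open whether an amine or a carboxylic acid in that place on the core of compound 1 would yield a number rather than a limit, which would allow the two cores to be compared.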